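From bromo to trifluoromethyl in a cytotoxicity series

The source may hold more compounds than are shown below. What is called first, only, known or untested is meant among the compounds shown, and "the series" means these compounds.

Compound 1 `O=Cc1cn(Cc2cccc(C(F)(F)F)c2)c2ccccc12` gives 1780 nM
Compound 2 `OCc1cn(Cc2cccc(Cl)c2)c2ccccc12` gives 160 nM
Compound 3 `OCc1cn(Cc2cccc(Br)c2)c2ccccc12` gives 32 nM

All three values come from a functional assay on T29Kt1 cells (Homo sapiens) for cytotoxicity, read by sulforhodamine B assay, with a stated time of 3 days (on this read-out lower numbers stand for stronger inhibition and higher numbers for weaker inhibition), and compound 3 stands lowest among them, with both of its gaps beyond the scatter. Compound 4 `OCc1cn(Cc2cccc(C(F)(F)F)c2)c2ccccc12` has not yet been measured. It departs from compound 3 by a single exchange, trifluoromethyl in place of bromo on an aromatic carbon, meta to a large group, and trifluoromethyl in place of bromo on an aromatic carbon sets out what changes. The closest measured evidence is a 5.0-fold lower number from compound 2 to compound 3 (0.70 log units; beyond the scatter) for bromo in place of chloro on an aromatic carbon, a modest step. Trifluoromethyl also appears in compound 1, whose 1780 nM in this assay comes with a different group elsewhere on the shared core, so it is only a loose guide. Within the data shown here, no measured step exchanges bromo for trifluoromethyl. A modest move toward a higher number is therefore expected, and the estimated step is a 2.8-fold higher number from compound 3 to compound 4 (0.45 log units; beyond the scatter) on this reasoning. For compound 4 the estimate is 90 nM with an expected range from 25 nM to 350 nM in this measurement.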

Compound 4, half-maximal inhibitory concentration: 560 nM
Compound 4: middle estimate off by 6.2-fold (0.79 log units), on the low side; measured number outside the range, above it.
By their numbers in this assay, from the lowest: compound 3; then compound 2; then compound 4; then compound 1.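

In this assay this aromatic carbon proves far less tolerant of trifluoromethyl than the bromo result suggested: the exchange gives an 18-fold higher number from compound 3 to compound 4 (1.24 log units; beyond the scatter) and is a large step, and the comparison with chloro gives a 3.5-fold higher number from compound 2 to compound 4 (0.54 log units; beyond the scatter) and places trifluoromethyl behind both halogens here. With trifluoromethyl held in place, the other site can now be read on its own, since hydroxymethyl in place of formyl gives a 3.2-fold lower number from compound 1 to compound 4 (0.50 log units; beyond the scatter) and shows that this site matters too, though by less than the exchange of bromo for trifluoromethyl. Nothing in hand explains why trifluoromethyl falls so far behind bromo.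

Going by these compounds, how a methoxy, a nitrile or an iodo group would rank at this aromatic carbon remains open. So does the outcome of placing an amine or a carboxylic acid where the hydroxymethyl sits.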